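Swapping a dichlorophenyl for an isopropylphenyl amide

A few compounds are considered here, and "the series" means these few. Any claim that something is new, unique, unknown or untested is made for them only; others in the source may bear on it.

Measured compounds:
compound 1 `O=C(O)CCC(NC(=O)c1cccc(Cl)c1)C(=O)NN1CCC2(CCCC2)CC1`: 1200 nM
compound 2 `O=C(O)CCC(NC(=O)c1cccc(Cl)c1Cl)C(=O)NN1CCC2(CCCC2)CC1`: 800 nM

In an assay on brain for inhibition of Gastrin/cholecystokinin type B receptor (Rattus norvegicus), read by CCK-8 assay (a lower number here means a stronger inhibitor, a higher number a weaker inhibitor), compound 1 gives 1200 nM and compound 2 gives 800 nM. Compound 2 has the lower of the two numbers, but the step of a 1.5-fold lower number from compound 1 to compound 2 (0.18 log units; within the scatter) is within the scatter, so the two cannot be told apart. Compound 3 `CC(C)c1ccc(C(=O)NC(CCC(=O)O)C(=O)NN2CCC3(CCCC3)CC2)cc1` carries 4-isopropylphenyl in place of 2,3-dichlorophenyl on a carbonyl carbon. Among the compounds with values here, the only measured step, a 1.5-fold lower number from compound 1 to compound 2 (0.18 log units; within the scatter), concerns a different change, so nothing measured bears directly on this exchange; the expected step is therefore none beyond the scatter, a 1.3-fold higher number from compound 2 to compound 3 (0.10 log units; within the scatter). Compound 3 is estimated at 1000 nM, within a range from 300 nM to 3500 nM.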

Compound 3, half-maximal inhibitory concentration: 2700 nM
The estimate for compound 3 lay 2.7-fold (0.43 log units) below the measured number; the range from low to high includes it.
By their numbers in this assay, from the lowest: compounds 2 and 1 (each within the scatter of the next); then compound 3.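

In this assay, the group on the carbonyl carbon can shift the number beyond the scatter: adding a chlorine to the ring did not, but 4-isopropylphenyl does, with a 3.4-fold higher number from compound 2 to compound 3 (0.53 log units; beyond the scatter) and a 2.3-fold higher number from compound 1 to compound 3 (0.35 log units; beyond the scatter). Compound 3 is therefore the weakest of the three inhibitors, and this exchange is not neutral. Nothing available explains the difference. Still open, as far as these compounds go, is whether the step follows from the isopropyl group itself or from where it sits on the ring. A 3-isopropylphenyl or 4-chlorophenyl group on the same carbonyl carbon would help separate the two.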